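Urea series: methoxy for methoxycarbonyl on the aryl ring

The source may report more compounds than this note shows. Statements on the series, on what has been measured and on what is new or still open speak of the compounds shown alone.

Working notes on the urea series. Compound 1 `COC(=O)c1ccc(NC(=O)Nc2cc(C)nc3ccccc23)cc1` was run in an ADME assay on Raji cells (Homo sapiens) for cytotoxicity, with a stated time of 72 h (on this read-out higher numbers stand for an effect only at larger amounts of compound and lower numbers for an effect already at smaller amounts), where compound 1 gives 17000 nM. Among the compounds with values here, compound 2 `Cc1cc(NC(=O)Nc2cccc(OC(F)(F)F)c2)c2ccccc2n1` gives 9000 nM in this assay; of these two numbers the one for compound 1 is the upper, but the gap between compound 1 and compound 2 lies within the scatter. Compound 3 `COc1ccc(NC(=O)Nc2cc(C)nc3ccccc23)cc1` carries the change (methoxy in place of methoxycarbonyl on an aromatic carbon). Within the data shown here, no measured pair shows this change, so no step beyond the scatter is expected. The number for compound 3 is estimated at 15000 nM, with a range from 5000 nM to 45000 nM. The expected step of a 1.1-fold lower number from compound 1 to compound 3 (0.05 log units; within the scatter) is taken to stay within the scatter.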

Compound 3, half-maximal effective concentration: > 25000 nM
Compound 3: no number, only a limit; the forecaster's own chance of this, stated with the estimate: 20%; at least 1.6-fold (0.22 log units) between middle value and limit.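

In this assay compound 3 gives > 25000 nM, which is a limit of the assay and not a number. Methoxy in place of methoxycarbonyl on an aromatic carbon, para to a large group, gives an at least 1.4-fold higher number from compound 1 to compound 3 (0.16 log units; that floor lies within the scatter), the first step read at this position, and its floor does not separate the two compounds. Only a floor can be read for this step: the limit of > 25000 nM in this assay, at which 1 of the 3 values shown sits.

On these data alone, how far compound 3 lies past its limit stays open. So does whether an amine or a carboxylic acid at this position would give a number inside the range of the assay.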